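Swapping Bromo for Methyl on the Shared Core

The source may report more compounds than this note shows. Statements on the series, on what has been measured and on what is new or still open speak of the compounds shown alone.

Going by the values given here, compound 1 `C/C(C(=O)NC1CC1)=C(/C)c1ccc(Br)cc1` is one of two compounds measured in a toxicity assay on the whole organism (strain Icem-CET (SPF Caw)) for cytotoxicity, with Mus musculus as the target; on this read-out higher numbers stand for an effect only at larger amounts of compound and lower numbers for an effect already at smaller amounts. In this assay compound 1 gives 100 mg/kg, the lowest of the two numbers shown; the nearest is compound 2 `C=CCNC(=O)/C(C)=C(\C)c1ccc(Br)cc1`, which in this assay gives 120 mg/kg. Among the compounds with values here, the single measured step, a 1.2-fold higher number from compound 1 to compound 2 (0.08 log units; within the scatter), exchanges the group on the amide-type nitrogen and stays within the scatter.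

Compound 3 `C/C(C(=O)NC1CC1)=C(/C)c1ccc(C)cc1` has not yet been measured in this assay. It differs from compound 1 as follows: methyl in place of bromo on an aromatic carbon. Within the data shown here, no measured step touches the aromatic carbon where this change sits, and the step from compound 1 to compound 2 alters a different part of the molecule, so it does not bear on the exchange of bromo for methyl. Among the measured compounds shown here, with no precedent among the measured compounds, the expectation is that this exchange gives no step beyond the scatter, an estimated shift of no change at the digits printed from compound 1 to compound 3 (within the scatter). Compound 3 is therefore expected to come out near 100 mg/kg, within a range from 50 mg/kg to 200 mg/kg.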

Compound 3, dose for half-maximal effect: 110 mg/kg
Compound 3: middle estimate off by 1.1-fold (0.04 log units), on the low side; the measured number falls inside the stated range.
By their numbers in this assay, from the lowest: compounds 1, 3 and 2 (each within the scatter of the next).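

In this assay, going by these compounds alone, the exchange of bromo for methyl on the aromatic carbon gives a 1.1-fold higher number from compound 1 to compound 3 (0.04 log units; within the scatter) and thereby provides the first measured step at this position, as the earlier step concerned only the group on the amide-type nitrogen. With the cyclopropyl group on that nitrogen held in place, this read-out does not separate bromo from methyl, two groups of one heavy atom each, at this place on the shared core. Nothing at hand accounts for the two groups reading alike.

On these data alone, whether an amine, a carboxylic acid or a longer chain at this place would move the number beyond the scatter remains open, since the two groups compared here are both single-atom groups without hydrogen-bond donors or acceptors. As far as these compounds go, it is also open whether the exchange of bromo for methyl would read the same with allyl instead of cyclopropyl on the amide-type nitrogen, as this step rests on the cyclopropyl compounds alone.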